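This account rests on a few compounds, and the source may have more. Where it says the series, first, only, none or still open, it means among the compounds named here.

Measured compounds:
Compound 1 `OC[C@H]1O[C@@H](n2cnc3c(NCc4ccccc4Cl)ncnc32)[C@H](O)[C@@H]1O` — in a functional assay on B16 cells (Mus musculus) for antiproliferative activity, with a stated time of 72 h (on this read-out higher numbers stand for weaker inhibition and lower numbers for stronger inhibition), compound 1 gives > 166000 nM, a limit of the assay.
Compound 2 `OC[C@H]1O[C@@H](n2cnc3c(NCc4ccc(Br)cc4)ncnc32)[C@H](O)[C@@H]1O` — in this assay compound 2 gives > 166000 nM, a limit of the assay.
Compound 3 `Cc1cccc(CNc2ncnc3c2ncn3[C@@H]2O[C@H](CO)[C@@H](O)[C@H]2O)c1O` — in this assay compound 3 gives > 166000 nM, a limit of the assay.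

Compound 2 stands at a limit only, as do the other two values shown: the limit of > 166000 nM in this assay, at which 3 of the 3 values shown sit. Within the data shown here, none of the measured steps can be read in size: a step that the two limits leave unreadable from compound 1 to compound 2, a step that the two limits leave unreadable from compound 1 to compound 3 and a step that the two limits leave unreadable from compound 2 to compound 3 are all left unreadable by the two limits at either end.

Compound 4 `Cc1ccc(O)c(CNc2ncnc3c2ncn3[C@@H]2O[C@H](CO)[C@@H](O)[C@H]2O)c1` is not yet measured. Its difference from compound 2: 2-hydroxy-5-methylphenyl in place of 4-bromophenyl on a saturated chain carbon bound to a nitrogen on an aromatic ring. Among the measured compounds shown here, the steps that bear on it are those around compound 2 and compound 3, and all of them are unreadable, so no size or direction of step beyond the scatter can be derived in this assay; the only information is that every measured value of this series sits at the limit.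

Compound 4 is therefore expected to remain at or near the limit, with an estimated value of 200000 nM (range 50000 nM to 1000000 nM), most probably reported as a limit only. The step from compound 2 to compound 4 is expected to be a step that the limit leaves unreadable from compound 2 to compound 4, which is no more than a placeholder for a change that cannot be read.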

Compound 4, half-maximal inhibitory concentration: > 166000 nM
Compound 4: no number, only a limit; the forecaster's own chance of this, stated with the estimate: 85%; the middle value lies beyond the limit too.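

In this assay compound 4 gives > 166000 nM, a limit of the assay. Its steps from compound 1, compound 2 and compound 3 cannot be read in size. The compounds shown leave open whether any benzyl group on the shared core yields a measurable inhibition value: the limit of > 166000 nM in this assay, at which 4 of the 4 values shown sit.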